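Sulfonyl aryl change at compound 2

The compounds below may be only part of what the source reports. "The series", "measured", "known", "first", "only" and "open" are said of these compounds alone.

In a functional assay on HL-60 cells (Homo sapiens) for cytotoxicity, read by MTT assay (on this read-out higher numbers stand for weaker inhibition and lower numbers for stronger inhibition), compound 1 `COc1ccc(S(=O)(=O)NC(C)C2=CC(=O)c3c(O)ccc(O)c3C2=O)c(OC)c1` gives 500 nM, and compound 2 `CC(NS(=O)(=O)c1ccc(F)cc1)C1=CC(=O)c2c(O)ccc(O)c2C1=O` gives 90 nM, the lower of the two numbers. Compound 3 `CC(NS(=O)(=O)c1ccccc1Br)C1=CC(=O)c2c(O)ccc(O)c2C1=O` differs from compound 2 by 2-bromophenyl in place of 4-fluorophenyl on a sulfonyl sulfur. Among the measured compounds shown here, one measured step bears on this place: a 5.6-fold lower number from compound 1 to compound 2 (0.74 log units; beyond the scatter), a modest change. For the measured compounds named here, no measured compound carries 2-bromophenyl, so that step gives only a rough scale. Going by the values given here, no step clearly beyond the scatter is expected, with a lean toward a higher number: the estimated change is a 1.7-fold higher number from compound 2 to compound 3 (0.22 log units; within the scatter). For compound 3 the expected value is 150 nM, with an estimated range of 50 nM to 450 nM.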

Compound 3, half-maximal inhibitory concentration: 120 nM
Beside the measured number, compound 3's estimate is 1.3-fold (0.10 log units) above it; the range from low to high includes it.
By their numbers in this assay, from the lowest: compounds 2 and 3 (each within the scatter of the next); then compound 1.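

In this assay, the change at the sulfonyl sulfur from 4-fluorophenyl to 2-bromophenyl gives a 1.3-fold higher number from compound 2 to compound 3 (0.12 log units; within the scatter), so the two aryl groups cannot be told apart here. The second comparison, a 4.2-fold lower number from compound 1 to compound 3 (0.62 log units; beyond the scatter), shows that the gap to the 2,4-dimethoxyphenyl compound is not confined to 4-fluorophenyl. No evidence on the origin of these steps is at hand.

Still open, from the compounds shown here alone, is how this position responds to a group without an aromatic ring, such as methyl or a longer alkyl chain. Also open, going by these compounds, is the effect of an aryl group carrying an amine or a carboxylic acid.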